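Swapping an amine side chain for an aryl imine

A few compounds are considered here, and "the series" means these few. Any claim that something is new, unique, unknown or untested is made for them only; others in the source may bear on it.

Measured in a functional assay on the whole organism (strain albino) for inhibition, with Rattus norvegicus as the target, read by paw edema, with stated times of 1 h and 2 h, at a dose of 20 mmol/kg by the intraperitoneal route; a higher number here means more inhibition at the dose given (going by the name of the read-out), a lower number less inhibition:
Compound 1 `N#CC1=C(NCN2CCCC2)N(c2ccccc2)C(=O)N2CCCCC(N3CCCC3)C12` gives 26.6%.
Compound 2 `N#CC1=C(/N=C/Nc2ccc([N+](=O)[O-])cc2)N(c2ccccc2)C(=O)N2CCCCC(N3CCCC3)C12` gives 41.5%.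
Compound 3 `CCOC(=O)C(=O)NC1=C(C#N)C2C(N3CCCC3)CCCCN2C(=O)N1c1ccccc1` gives 83.6%.

Compound 1 stands lowest of these three numbers, with compound 2 nearest and compound 3 furthest. Compound 4 `COc1ccc(/C=N/C2=C(C#N)C3C(N4CCCC4)CCCCN3C(=O)N2c2ccccc2)cc1` differs from compound 1 in one place: a group of 10 heavy atoms (8 carbon, 1 nitrogen, 1 oxygen; one six-membered aromatic ring of carbon only) in place of a group of 7 heavy atoms (5 carbon, 2 nitrogen; one five-membered non-aromatic ring with 1 hetero atom), on a double-bonded ring carbon. The most comparable measured step is a number 14.9 percentage points higher from compound 1 to compound 2 (beyond the scatter), which likewise brought a six-membered aromatic ring in place of the same five-membered ring on the same double-bonded ring carbon. The step of a number 57 percentage points higher from compound 1 to compound 3 (beyond the scatter) put in a group with no ring and so bears less on this change. A modest rise is therefore expected, a number 15.4 percentage points higher from compound 1 to compound 4 (beyond the scatter). Compound 4 is estimated at 42%, with a range from 26% to 62%.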

Compound 4, a percentage reported as inhibition, in the whole organism at one dose (the size of the read-out at that dose, not a potency): 71.6%
Compound 4: the middle estimate sits 29.6 percentage points below what was measured; measured number outside the range, above it.
By their numbers in this assay, from the lowest: compound 1; then compound 2; then compound 4; then compound 3.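

Changing only the group on the carbon with a double bond to nitrogen, 4-methoxyphenyl in place of (4-nitrophenyl)amino, gives a number 30.1 percentage points higher from compound 2 to compound 4 (beyond the scatter) so an aromatic ring at this position does not by itself fix the outcome. Its large size as a step shows in a number 45 percentage points higher from compound 1 to compound 4 (beyond the scatter) and puts this aryl group far ahead of ((pyrrolidin-1-yl)methyl)amino. Yet the ringless (ethoxycarbonyl)carbonyl group stays ahead, with a number 12 percentage points lower from compound 3 to compound 4 (beyond the scatter) as the modest step. Nothing shown explains these steps. From the compounds shown here alone, whether the methoxy group itself matters stays open, as a plain phenyl or a 4-hydroxyphenyl group would test.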